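Working notes: replacing the side chain of compound 2

The source may report more compounds than this note shows. Statements on the series, on what has been measured and on what is new or still open speak of the compounds shown alone.

Measured so far in a functional assay on HL-60 cells (Homo sapiens) for cytotoxicity, read by WST assay, with a stated time of 48 h; on this read-out lower numbers stand for stronger inhibition and higher numbers for weaker inhibition
compound 1 `COC[C@H](C)[C@H](C)C(c1ccc(O)c(OC)c1)c1ccc(O)c(OC)c1` gives 82000 nM
compound 2 `COc1cc(C(c2ccc(O)c(OC)c2)[C@@H](C)[C@H](C)CF)ccc1O` gives 32000 nM

Compound 2 holds the lower of the two numbers, and the gap to compound 1 lies beyond the scatter. The next structure is compound 3 `CC[C@H](C(C)C)C(c1ccc(O)c(OC)c1)c1ccc(O)c(OC)c1`, which keeps the shared core. It carries 1-isopropylpropyl in place of 2-(fluoromethyl)-1-methylpropyl on a saturated chain carbon bound to two aromatic carbons.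

For the measured compounds named here, only one measured step bears on this change, and only indirectly. It shows a 2.6-fold lower number from compound 1 to compound 2 (0.41 log units; beyond the scatter), a modest step made within the same side chain. Going by the values given here, no measured compound has a side chain without a heteroatom, so the direction in this assay remains open. A step no larger than that modest one is expected, most likely within the scatter. The estimate means a 1.2-fold lower number from compound 2 to compound 3 (0.09 log units; within the scatter), an expected step of small size. Compound 3 is estimated at 26000 nM, with an expected range from 10000 nM to 65000 nM.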

Compound 3, half-maximal inhibitory concentration: 16000 nM
Estimate against measurement, compound 3: 1.6-fold (0.21 log units) above; the measured number falls inside the stated range.
By their numbers in this assay, from the lowest: compounds 3 and 2 (each within the scatter of the next); then compound 1.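

In this assay, 1-isopropylpropyl on a saturated chain carbon bound to two aromatic carbons gives a 2.0-fold lower number from compound 2 to compound 3 (0.30 log units; within the scatter) and so stands level with the 2-(fluoromethyl)-1-methylpropyl chain, which shows that a side chain made of carbon alone can match the fluorinated one in this read-out. The same replacement gives a 5.1-fold lower number from compound 1 to compound 3 (0.71 log units; beyond the scatter) against the 2-(methoxymethyl)-1-methylpropyl chain, so compound 1 is now separated beyond the scatter from both compound 2 and compound 3, while those two are not separated from each other. No measured evidence at hand accounts for these numbers.

The change from compound 2 to compound 3 alters both the atoms and the branching of the chain, and the number of defined stereocentres falls from 2 to 1, so these compounds do not separate the contribution of each. Also open is how this position responds to an amine, a carboxylic acid, a longer chain or a cyclohexyl ring in place of the branched saturated chains shown here.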